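Carbamoyl in Place of Cyano: An Expected Step

A few compounds are considered here, and "the series" means these few. Any claim that something is new, unique, unknown or untested is made for them only; others in the source may bear on it.

In a functional assay (brain) for inhibition, with Rattus norvegicus as the target (a lower number here means a stronger inhibitor, a higher number a weaker inhibitor), compound 1 `COc1ccc(NC(=O)N2CCC(c3c[nH]c4ccc(F)cc34)CC2)cc1N1CCN(C)CC1` gives 21 nM and compound 2 `COc1ccc(NC(=O)N2CCC(c3c[nH]c4cc(F)ccc34)CC2)cc1N1CCN(C)CC1` gives 49 nM, which is a 2.3-fold higher number from compound 1 to compound 2 (0.37 log units; beyond the scatter). Compound 3 `COc1ccc(NC(=O)N2CCC(c3c[nH]c4ccc(C#N)cc34)CC2)cc1N1CCN(C)CC1` stands lowest of the three at 1.9 nM, with an 11-fold lower number from compound 1 to compound 3 (1.04 log units; beyond the scatter) and a 26-fold lower number from compound 2 to compound 3 (1.41 log units; beyond the scatter). Compound 4 `COc1ccc(NC(=O)N2CCC(c3c[nH]c4ccc(C(N)=O)cc34)CC2)cc1N1CCN(C)CC1` carries carbamoyl in place of cyano on an aromatic carbon. Within the data shown here, no measured step tests carbamoyl directly. Among the measured compounds shown here, the two large steps show only that an exchange of this kind can move the number far. For the measured compounds named here, from the lowest number so far, a moderate rise is expected, a 3.2-fold higher number from compound 3 to compound 4 (0.50 log units; beyond the scatter). Compound 4 is estimated at 6 nM, with an expected range from 1.5 nM to 25 nM.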

Compound 4, half-maximal inhibitory concentration: 472 nM
For compound 4 the middle estimate is 79-fold (1.90 log units) below the measured one; the whole stated range lies below it.
By their numbers in this assay, from the lowest: compound 3; then compound 1; then compound 2; then compound 4.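

In this assay the exchange of cyano for carbamoyl on the same aromatic carbon gives a 250-fold higher number from compound 3 to compound 4 (2.40 log units; beyond the scatter), so this place does not treat these two small groups alike. Carbamoyl also falls behind both fluoro compounds, with a 22-fold higher number from compound 1 to compound 4 (1.35 log units; beyond the scatter) on the same carbon and a 9.6-fold higher number from compound 2 to compound 4 (0.98 log units; beyond the scatter) when set against the 6-fluoro-1H-indol-3-yl compound. Among the groups shown at this place, cyano gives the lowest number and carbamoyl the highest.

On these data alone, whether a carboxylic acid or an aminomethyl group here would behave like carbamoyl stays open. Nothing available explains why the number rises so far with carbamoyl.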